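The compounds below may be only part of what the source reports. "The series", "measured", "known", "first", "only" and "open" are said of these compounds alone.

Working notes on the series. Compound 1 `CCCCCCCCc1ccc([C@H]2CC[C@H](N)CC2)cc1` gives 29000 nM in an in vitro assay on Sf9 cells for inhibition of sphingosine kinase 2 (Mus musculus), read by scintillation proximity assay; a lower number here means a stronger inhibitor, a higher number a weaker inhibitor. Compound 2 `CCCCCCCCc1ccc([C@H]2CC[C@H](N(C)C)CC2)cc1` gives 27000 nM in this assay. The only step recorded so far, a 1.1-fold lower number from compound 1 to compound 2 (0.03 log units; within the scatter), leaves the two numbers side by side; on the numbers shown, compound 2 and compound 1 cannot be told apart, and no separation between them is established.

Compound 3 `CCCCCCCCc1ccc([C@H]2CC[C@H](NCCO)CC2)cc1` is not yet measured. It differs from compound 2 by (2-hydroxyethyl)amino in place of dimethylamino on a saturated ring carbon. Within the data shown here, the step that bears on this change is the one from compound 1 to compound 2, which swaps the substituent on the same saturated ring carbon and was a 1.1-fold lower number from compound 1 to compound 2 (0.03 log units; within the scatter), within the scatter. Among the measured compounds shown here, no step in the set moves the number beyond the scatter, so no step beyond the scatter is expected here either. Compound 3 is therefore expected to give about 25000 nM, with a range from 9000 nM to 70000 nM. This corresponds to an expected 1.1-fold lower number from compound 2 to compound 3 (0.03 log units; within the scatter).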

Compound 3, inhibition constant: 38000 nM
Estimate against measurement, compound 3: 1.5-fold (0.18 log units) below; low and high end bracket the measured number.
By their numbers in this assay, from the lowest: compounds 2, 1 and 3 (each within the scatter of the next).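

Hydroxyl-bearing substitution on the amine nitrogen is now covered at this saturated ring carbon: in this assay the step with an oxygen-bearing group gives a 1.4-fold higher number from compound 2 to compound 3 (0.15 log units; within the scatter) and the step that places 2-hydroxyethyl on the primary amine gives a 1.3-fold higher number from compound 1 to compound 3 (0.12 log units; within the scatter) on the same core. Amino, dimethylamino and (2-hydroxyethyl)amino therefore cannot be told apart here, so the added oxygen and the two further hydrogen-bond partners counted for the entering group leave no separation in the numbers. No supporting measurement bears on this result.

Going by these compounds, all three compounds keep a basic-looking amine only by name and stay in one narrow band, so it remains open whether any replacement at this carbon moves the number beyond the scatter. A carboxylic acid, an amide or a longer chain on the amine nitrogen would test that.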